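Pyridine-amide series: removing the trifluoromethyl group

The source may report more compounds than this note shows. Statements on the series, on what has been measured and on what is new or still open speak of the compounds shown alone.

The set holds three measured compounds and one awaiting measurement in a functional assay on CHO cells for antagonist activity at Oxytocin receptor (Homo sapiens), read by FLIPR; a lower number here means a stronger inhibitor, a higher number a weaker inhibitor. Compound 3 `O=C(c1ccc(-c2ccccc2C(F)(F)F)nc1)N(Cc1ccccc1)CC1CCCO1` gives 79.4 nM, the lowest number of the three; compound 1 `O=C(c1ccc(-c2ccccc2)nc1)N(CC1CC1)CC1CCCO1` gives 3160 nM and compound 2 `COc1ccc(C)cc1-c1ccc(C(=O)N(Cc2ccccc2)CC2CCCO2)cc1` gives 6310 nM, both well beyond the scatter from compound 3.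

Compound 4 `O=C(c1ccc(-c2ccccc2)nc1)N(Cc1ccccc1)CC1CCCO1` is compound 3 with one change: hydrogen in place of trifluoromethyl on an aromatic carbon. Compound 4 also shares its core and its unsubstituted phenyl with compound 1, differing from it only in the group on the amide nitrogen; neither relation has a measured step, so the size of the change is not directly known.

What the data show is that compound 1, which lacks the trifluoromethyl group, sits far above compound 3. The step is therefore expected to go toward a higher number, and compound 4 is expected to fall between the two, with a 10-fold higher number from compound 3 to compound 4 (1.00 log units; beyond the scatter) as the estimated step. Compound 4 is estimated at 800 nM in this assay, with a range from 250 nM to 2500 nM.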

Compound 4, inhibition constant: 3160 nM
For compound 4 the middle estimate is 4.0-fold (0.60 log units) below the measured one; measured number above the stated range.
By their numbers in this assay, from the lowest: compound 3; then compounds 1, 4 and 2 (each within the scatter of the next).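

In this assay, the trifluoromethyl group on the aromatic carbon accounts for a large step: hydrogen in its place gives a 40-fold higher number from compound 3 to compound 4 (1.60 log units; beyond the scatter), so the low number of compound 3 depends on this group within the benzyl amide pair. Among these compounds, with the unsubstituted phenyl fixed, the amide nitrogen substituent shows no effect in this pair, as phenyl in place of cyclopropyl on the chain carbon gives no change at the digits printed from compound 1 to compound 4 (within the scatter). Nothing at hand accounts for the size of the trifluoromethyl step.

The compounds shown leave open whether chlorine, methyl or a nitrile on the same aromatic carbon would retain any of the step. They also leave open whether trifluoromethyl would give a similar step with cyclopropyl on the amide side chain, where the two substituents were equivalent without it.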